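The compounds below may be only part of what the source reports. "The series", "measured", "known", "first", "only" and "open" are said of these compounds alone.

In an ADME assay on HepG2 cells (Homo sapiens) for cytotoxicity, with a stated time of 72 h (on this read-out higher numbers stand for an effect only at larger amounts of compound and lower numbers for an effect already at smaller amounts), compound 1 (`CCc1ccc(NC(=O)Nc2cc(C)nc3ccccc23)cc1`) gives 17000 nM and compound 3 (`Cc1cc(NC(=O)Nc2ccc(SC(F)(F)F)cc2)c2ccccc2n1`) gives 20000 nM and these two numbers lie within the scatter of each other. Compound 2 (`Cc1cc(NC(=O)Nc2ccc(O)cc2)c2ccccc2n1`) gives > 25000 nM as a limit and not a number. Compound 4 (`Cc1cc(NC(=O)Nc2ccc(N)cc2)c2ccccc2n1`) differs from compound 3 by amino in place of (trifluoromethyl)sulfanyl on an aromatic carbon para to a large group. Earlier swaps on this same aromatic carbon moved the read-out little: the steps (a 1.2-fold higher number from compound 1 to compound 3 (0.07 log units; within the scatter)) and (an at least 1.4-fold higher number from compound 1 to compound 2 (0.16 log units; that floor lies within the scatter)) and (an at least 1.2-fold lower number from compound 2 to compound 3 (0.09 log units; that floor lies within the scatter)) all stay within the scatter. The expected step in this assay is (a 1.1-fold higher number from compound 3 to compound 4 (0.04 log units; within the scatter)) and so none beyond the scatter. For compound 4 the expected value is 22000 nM with 10000 nM to 40000 nM as its estimated range.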

Compound 4, half-maximal effective concentration: > 25000 nM
Compound 4 ended at the assay's limit (the forecaster's own chance of this, stated with the estimate: 40%); at least 1.1-fold (0.05 log units) between middle value and limit.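

On this aromatic carbon, amino joins hydroxy as a group whose result in this assay is a limit, while ethyl and (trifluoromethyl)sulfanyl give numbers. Yet an at least 1.2-fold higher number from compound 3 to compound 4 (0.09 log units; that floor lies within the scatter) and an at least 1.4-fold higher number from compound 1 to compound 4 (0.16 log units; that floor lies within the scatter) are floors only, so neither shows a firm change. The step between compound 2 and compound 4 cannot be read, because both values are limits: the limit of > 25000 nM in this assay, at which 2 of the 4 values shown sit.

As far as these compounds go, how far the true values of compound 2 and compound 4 lie past that limit stays open. So does whether a carboxylic acid or a dimethylamino group on this carbon would give a number or another limit.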